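Changing one aryl group on a weak growth inhibitor

The source may report more compounds than this note shows. Statements on the series, on what has been measured and on what is new or still open speak of the compounds shown alone.

In a functional assay on OVCAR-3 cells (Homo sapiens) for antiproliferative activity, read by spectrophotometry, with a stated time of 2 days (on this read-out lower numbers stand for stronger inhibition of growth and higher numbers for weaker inhibition of growth), compound 1 `COc1cc(N2CCN(C(C)=O)CC2)ccc1Nc1ncc(C(F)(F)F)c(N2Cc3cccc(N(C)S(C)(=O)=O)c3C2)n1` gives 1600 nM, and compound 3 `CN(c1cccc2c1CN(c1nc(Nc3cccc(Oc4ccccc4)c3)ncc1C(F)(F)F)C2)S(C)(=O)=O` gives 24900 nM. Compound 2 `COc1cc(Nc2ncc(C(F)(F)F)c(N3Cc4cccc(N(C)S(C)(=O)=O)c4C3)n2)c(OC)cc1Cl` stands at > 30000 nM, which is a limit of the assay and not a number. Compound 4 `CN(c1cccc2c1CN(c1nc(Nc3ccc(Cl)c(C(F)(F)F)c3)ncc1C(F)(F)F)C2)S(C)(=O)=O` keeps the core of compound 2 but places 4-chloro-3-(trifluoromethyl)phenyl in place of 4-chloro-2,5-dimethoxyphenyl on a nitrogen on an aromatic ring. For the measured compounds named here, no measured pair of compounds shows what this exchange does. In this assay, a modest expected move towards stronger inhibition of growth, an at least 2.1-fold lower number from compound 2 to compound 4 (0.33 log units; beyond the scatter), rests only on compound 3 at 24900 nM. For compound 4 the estimated value is 14000 nM, with an expected range from 4000 nM to 30000 nM.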

Compound 4, concentration for 50% growth inhibition: > 50000 nM
Compound 4 ended at the assay's limit; the forecaster's own chance of this, stated with the estimate: 35%; middle value at least 3.5-fold (0.55 log units) away from the limit.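

Compound 2 and compound 4 both sit at a limit of this assay, and a limit is not a number, so no step can be read between them. The compounds shown leave open what 4-chloro-3-(trifluoromethyl)phenyl in place of 4-chloro-2,5-dimethoxyphenyl does to growth inhibition, in size or direction.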